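The source may report more compounds than this note shows. Statements on the series, on what has been measured and on what is new or still open speak of the compounds shown alone.

Three members of a small amide series built on a shared core were examined in an ADME assay on RAW264.7 cells (Mus musculus) for cytotoxicity, read by MTT assay, with a stated time of 72 h, tested at 50 uM; on this read-out lower numbers stand for a weaker effect and higher numbers for a stronger effect at the one concentration tested. Compound 1 `O=C(Cn1c(=O)oc2cc(Cl)ccc21)NCc1cccs1` gives 20.3% in this assay. Compound 3 `O=C(Cn1c(=O)oc2cc([N+](=O)[O-])ccc21)NCc1cccs1`, which carries nitro in place of chloro on an aromatic carbon, gives 36.6% in this assay, so that change produced a number 16.3 percentage points higher from compound 1 to compound 3 (beyond the scatter). Compound 2 `O=C(Cn1c(=O)oc2cc(Cl)ccc21)Nc1cc(C(F)(F)F)ccc1Cl` gives 1.61% in this assay, the weakest effect of the three, and the difference between its core and that of compound 1 is not broken down here.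

Compound 4 `O=C(Cn1c(=O)oc2cc([N+](=O)[O-])ccc21)Nc1cc(C(F)(F)F)ccc1Cl` has not yet been measured in this assay. It differs from compound 2 by nitro in place of chloro on an aromatic carbon, the same change, at the same place, that separates compound 1 from compound 3. Compound 4 is expected to show a number 10.4 percentage points higher from compound 2 to compound 4 (beyond the scatter), a step estimated from the rise seen in a number 16.3 percentage points higher from compound 1 to compound 3 (beyond the scatter) and tempered because compound 2 starts from 1.61%, which leaves uncertain whether a step of that size carries over. On that basis compound 4 is expected to give about 12% in this assay, most likely between 0% and 30%.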

Compound 4, a percentage reported as inhibition, at one concentration (the size of the read-out at that concentration, not a potency): 12.8%
Compound 4: the middle estimate sits 0.8 percentage points below what was measured, within the range that was stated.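

In this assay, nitro in place of chloro on an aromatic carbon gave a number 11.2 percentage points higher from compound 2 to compound 4 (beyond the scatter), so the rise seen with the core of compound 1 appeared again on the core of compound 2. Set side by side, the two steps do not separate: the same change on two cores in this assay, a number 16.3 percentage points higher (beyond the scatter) from compound 1 to compound 3 and a number 11.2 percentage points higher (beyond the scatter) from compound 2 to compound 4, 5.1 percentage points apart, within the scatter of two such steps. This shows that the change carried over between these two pairs at the one concentration tested, but two pairs do not establish a rule for other amides in the series, and they give no reason for the rise.

The compounds shown compare only chloro and nitro at this one place on the ring, so it remains open how an amine, a carboxylic acid or a nitrile there would read in this assay. Also open, on these data alone, is whether the step would hold on a core with a longer chain on the amide nitrogen, or at other concentrations.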